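The compounds below may be only part of what the source reports. "The series", "measured", "known", "first", "only" and "open" are said of these compounds alone.

Measured so far:
compound 1 `O=C(N/N=C/c1ccc([N+](=O)[O-])cc1)c1cn(C2CC2)c2cc(N3CCNCC3)c(F)cc2c1=O` — 25000 nM
compound 2 `O=C(N/N=C/c1ccc(F)cc1)c1cn(C2CC2)c2cc(N3CCNCC3)c(F)cc2c1=O` — 25000 nM

Notes. In a toxicity assay on CHO cells (Cricetulus griseus) for cytotoxicity, read by MTT assay (a higher number here means a weaker inhibitor, a lower number a stronger inhibitor), compound 1 gives 25000 nM. Compound 2 gives 25000 nM. Among the compounds with values here, the only step in hand, no change at the digits printed from compound 1 to compound 2 (within the scatter), exchanged the nitro and left the read-out unchanged, so compound 1 stands level with compound 2.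

Compound 3 `COc1ccc(/C=N/NC(=O)c2cn(C3CC3)c3cc(N4CCNCC4)c(F)cc3c2=O)cc1` differs from compound 1 by methoxy in place of nitro on an aromatic carbon. Within the data shown here, the one step that bears on this again removes the nitro, and it was flat; another replacement of the same group is therefore expected to show no step beyond the scatter, no change at the digits printed from compound 1 to compound 3 (within the scatter). Compound 3 is expected at 25000 nM, within 12000 nM to 50000 nM.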

Compound 3, half-maximal inhibitory concentration: 25000 nM
Estimate against measurement, compound 3: no gap at the digits printed; the measured number falls inside the stated range.
By their numbers in this assay, from the lowest: compounds 1, 2 and 3 (each within the scatter of the next).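

In this assay, the change from 4-nitrophenyl to 4-methoxyphenyl gives no change at the digits printed from compound 1 to compound 3 (within the scatter) and methoxy in place of fluoro gives no change at the digits printed from compound 2 to compound 3 (within the scatter) on the same aromatic carbon. Three groups at this place, para to a large group, now read alike on the shared core, where the earlier pair offered only nitro and fluoro. No measurement in hand accounts for this flat reading.
From the compounds shown here alone, whether an amine or a carboxylic acid on this carbon would move the read-out stays open, as does the effect of a longer chain there.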